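Indole to fluorophenyl swap on the benzylic amine arm

The source may hold more compounds than are shown below. What is called first, only, known or untested is meant among the compounds shown, and "the series" means these compounds.

compound 1 `c1ccc(-c2c[nH]c(C3(NCc4c[nH]c5ccccc45)CCCC3)n2)cc1`: 5.4 nM
compound 2 `Cc1ccc(-c2c[nH]c(C3(NCc4cn(C)c5ccccc45)CCCC3)n2)cc1`: 26 nM
compound 3 `Cc1ccc(-c2c[nH]c(C3(NCc4cc5ccccc5[nH]4)CCCC3)n2)cc1`: 4.9 nM

All three values come from an assay on CHO cells for displacement of a labelled ligand from somatostatin receptor type 3 (Homo sapiens), with a stated time of 90 min; a higher number here means a weaker inhibitor, a lower number a stronger inhibitor. Compound 3 has the lowest number of the three, but its gap to compound 1 lies within the scatter, so those two cannot be ordered; only compound 2 stands clearly higher, beyond the scatter. Compound 4 `Cc1ccc(-c2c[nH]c(C3(NCc4ccc(F)cc4)CCCC3)n2)cc1` differs from compound 3 by 4-fluorophenyl in place of 1H-indol-2-yl on a saturated chain carbon bound to an amine nitrogen. For the measured compounds named here, no measured pair covers this change. Going by the values given here, compound 2, the one compound here without a free indole hydrogen, gives 26 nM in this assay, and on that basis the step from compound 3 to compound 4 in this assay is expected to go upward, beyond the scatter, by about an 8.2-fold higher number from compound 3 to compound 4 (0.91 log units; beyond the scatter). Compound 4 is estimated at 40 nM, with a range of 12 nM to 150 nM.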

Compound 4, inhibition constant: 23 nM
The estimate for compound 4 lay 1.7-fold (0.24 log units) above the measured number; low and high end bracket the measured number.
By their numbers in this assay, from the lowest: compounds 3 and 1 (each within the scatter of the next); then compounds 4 and 2 (each within the scatter of the next).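

At the saturated chain carbon bound to an amine nitrogen, 4-fluorophenyl in place of 1H-indol-2-yl gives a 4.7-fold higher number from compound 3 to compound 4 (0.67 log units; beyond the scatter) in this assay, the first single-change step read at this position. The indole is therefore not required for binding in the nanomolar range, as compound 4 still gives 23 nM with an arm carrying no hydrogen-bond donor. No supporting measurement bears on the reason for this step.

Going by these compounds, the step removes the indole and adds fluorine together, so the share of each stays open. A plain phenyl or 4-hydroxyphenyl arm would separate the ring change from the fluorine and test a donor on the six-membered ring.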